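Dropping a Methoxy Group from an Inactive Compound

The source may report more compounds than this note shows. Statements on the series, on what has been measured and on what is new or still open speak of the compounds shown alone.

In a functional assay on NCI-H460 cells (Homo sapiens) for cytotoxicity, read by MTT assay, with a stated time of 48 h (a higher number here means a weaker inhibitor, a lower number a stronger inhibitor), compound 1 `COc1ccc2[nH]c(=O)c(-c3nc4cc(F)ccc4[nH]3)cc2c1` reaches only a limit, namely > 100000 nM. Compound 2 `COc1ccc2[nH]c(=O)c(-c3nc4cc(C)c(C)cc4[nH]3)cc2c1` likewise gives only the limit of > 100000 nM in this assay. Both values thus sit where the assay stops counting, (the limit of > 100000 nM in this assay, at which 2 of the 2 values shown sit). Compound 3 `Cc1cc2nc(-c3cc4ccccc4[nH]c3=O)[nH]c2cc1C` differs from compound 2 by hydrogen in place of methoxy on an aromatic carbon. Going by the values given here, no measured step of this kind exists, so no shift beyond the scatter is expected, and the expected step that the limit leaves unreadable from compound 2 to compound 3 in this assay is an estimate only. Compound 3 is estimated at 200000 nM in this assay, within 50000 nM to 1000000 nM, most likely again reported as a limit.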

Compound 3, half-maximal inhibitory concentration: > 100000 nM
Compound 3: only a limit was reported; the forecaster's own chance of this, stated with the estimate: 80%; the middle value does not contradict the limit.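

Compound 2 and compound 3 both stop at the limit of this assay, so no step between them can be read: the limit of > 100000 nM in this assay, at which 3 of the 3 values shown sit.

As far as these compounds go, whether hydrogen in place of methoxy changes potency at all in this assay stays open.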